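Sulfur for oxygen on the shared core: compound 4

The source may report more compounds than this note shows. Statements on the series, on what has been measured and on what is new or still open speak of the compounds shown alone.

Measured so far in a functional assay on NCI/ADR-RES cells (Homo sapiens) for inhibition, read by sulforhodamine B assay, with a stated time of 48 h; a higher number here means that more compound is tolerated, a lower number that less compound is tolerated:
compound 1 `Nc1cc(N)c2nc(-c3ccccc3)c(Oc3ccc(Cl)c(Cl)c3)nc2c1`: < 100000 nM
compound 2 `Nc1cc(N)c2nc(-c3ccccc3)c(Sc3ccc(Cl)c(Cl)c3)nc2c1`: < 100000 nM
compound 3 `Nc1cc(N)c2nc(-c3ccccc3)c(Oc3ccc(F)cc3)nc2c1`: 70800 nM

The entry for compound 1 is a limit of this assay, not a number. The entry for compound 2 is likewise a limit. For the measured compounds named here, compound 3 therefore stands as the only real number in this assay, the other two entries being limits (the limit of < 100000 nM in this assay, at which 2 of the 3 values shown sit). In consequence none of the steps among these three can be sized: a step that the two limits leave unreadable from compound 1 to compound 2, a step that the limit leaves unreadable from compound 1 to compound 3 and a step that the limit leaves unreadable from compound 2 to compound 3 all remain unreadable.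

Compound 4 `Nc1cc(N)c2nc(-c3ccccc3)c(Sc3ccc(F)cc3)nc2c1` differs from compound 3 by (4-fluorophenyl)sulfanyl in place of 4-fluorophenoxy on an aromatic carbon. Going by the values given here, the one measured step that carries the same exchange of an oxygen link for a sulfur link, a step that the two limits leave unreadable from compound 1 to compound 2, has no readable size, so no direction can be drawn from it. With nothing in this assay pointing up or down, the expectation is no step beyond the scatter, held with a wide range. Compound 4 is expected to give about 70000 nM in this assay, between 20000 nM and 200000 nM. This corresponds to an expected step of a 1.0-fold lower number from compound 3 to compound 4 (0.00 log units; within the scatter), estimated as flat.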

Compound 4, concentration lethal to 50% of the cells: 72400 nM
The estimate for compound 4 lay 1.0-fold (0.01 log units) below the measured number; measured number inside the range.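

In this assay, for the compounds shown here, the exchange of an oxygen link for a sulfur link at this position now has a readable size for the first time, with a 1.0-fold higher number from compound 3 to compound 4 (0.01 log units; within the scatter). With the 4-fluorophenyl group held constant, 4-fluorophenoxy and (4-fluorophenyl)sulfanyl on this aromatic carbon next to the ring nitrogen cannot be told apart in this read-out. The steps that involve compound 1 or compound 2 still cannot be read, as the entries for both compounds are limits of the assay: the limit of < 100000 nM in this assay, at which 2 of the 4 values shown sit.

From the compounds shown here alone, whether the link atom matters with the 3,4-dichlorophenyl group stays open, as does how that group compares with 4-fluorophenyl on either link. Also open, going by these compounds, is what an amine link, or a longer chain between this aromatic carbon and the aryl ring, would do in this assay.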